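The source may hold more compounds than are shown below. What is called first, only, known or untested is meant among the compounds shown, and "the series" means these compounds.

Measured compounds in this series:
compound 1 `COC(=O)c1ccc(-c2ccc(N3CCN(C)CC3)c(NC(=O)c3cc(N)c(F)c(C)c3Cl)c2)cc1`, 3700 nM
compound 2 `Cc1c(F)c(N)cc(C(=O)Nc2cc(-c3ccc(NC(=O)C4CCN(C)CC4)cc3)ccc2N2CCN(C)CC2)c1Cl`, 3900 nM

In a physicochemical assay for solubility, using potentiometric titration, at pH 7.4 (on this read-out higher numbers stand for higher solubility and lower numbers for lower solubility), compound 2 gives 3900 nM, the highest of the two numbers; its nearest neighbour is compound 1 with 3700 nM, and the two lie within the scatter of each other.

The next compound, compound 3 `Cc1c(F)c(N)cc(C(=O)Nc2cc(-c3ccc(NC(=O)C4CCOCC4)cc3)ccc2N2CCN(C)CC2)c1Cl`, differs from compound 2 at the amide side chain: oxan-4-yl in place of 1-methylpiperidin-4-yl on a carbonyl carbon.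

Among the measured compounds shown here, the only measured step in this assay is a 1.1-fold higher number from compound 1 to compound 2 (0.02 log units; within the scatter), which exchanges a group at a different place on the shared core and does not involve the oxan-4-yl for 1-methylpiperidin-4-yl exchange. For the measured compounds named here, no measured step covers the present change, so no direction is fixed from the numbers. The expected step is a 2.0-fold lower number from compound 2 to compound 3 (0.29 log units; within the scatter), set with a wide range to reflect this gap. Compound 3 is therefore estimated at 2000 nM, between 500 nM and 6000 nM.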

Compound 3, solubility: 126000 nM
For compound 3 the middle estimate is 63-fold (1.80 log units) below the measured one, outside the stated range (above it).
By their numbers in this assay, from the lowest: compounds 1 and 2 (each within the scatter of the next); then compound 3.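

In this assay the group on the carbonyl carbon emerges as a position where the outcome can move far: oxan-4-yl in place of 1-methylpiperidin-4-yl gives a 32-fold higher number from compound 2 to compound 3 (1.51 log units; beyond the scatter) between two six-membered non-aromatic rings. With methoxycarbonyl as the reference, ((oxan-4-yl)carbonyl)amino gives a 34-fold higher number from compound 1 to compound 3 (1.53 log units; beyond the scatter) while ((1-methylpiperidin-4-yl)carbonyl)amino gave only a 1.1-fold higher number from compound 1 to compound 2 (0.02 log units; within the scatter) on the same aromatic carbon, so the amide alone does not set the number and the ring it carries matters. Nothing measured on these compounds accounts for the size of this step.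

Still open, going by these compounds, is how a piperidin-4-yl without the methyl or a cyclohexyl would read at this position. The compounds shown also leave open whether the oxan-4-yl step carries over to any other core.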